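Replacing 4-isopropylphenyl with 3-methoxyphenyl in compound 3

A few compounds are considered here, and "the series" means these few. Any claim that something is new, unique, unknown or untested is made for them only; others in the source may bear on it.

In an ADME assay on L02 cells (Homo sapiens) for inhibition, read by CCK-8 assay, with a stated time of 48 h (a higher number here means a weaker inhibitor of growth, a lower number a stronger inhibitor of growth), compound 3 `CC(C)c1ccc(Nc2nc(Nc3ccc(N4CCN(C)CC4)cn3)ncc2Cl)cc1` gives 13700 nM. In the same test, compound 1 `COc1cccc(CNc2nc(Nc3ccc(N4CCN(C)CC4)cn3)ncc2Cl)c1` gives 16200 nM and compound 2 `Cc1cccc(Nc2nc(Nc3ccc(N4CCN(C)CC4)cn3)ncc2Cl)c1` gives 6080 nM. Compound 3 therefore sits within the scatter of one neighbour, a 1.2-fold lower number from compound 1 to compound 3 (0.07 log units; within the scatter), and clearly apart from the other, a 2.3-fold higher number from compound 2 to compound 3 (0.35 log units; beyond the scatter).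

Compound 4 `COc1cccc(Nc2nc(Nc3ccc(N4CCN(C)CC4)cn3)ncc2Cl)c1` has 3-methoxyphenyl in place of 4-isopropylphenyl on a nitrogen on an aromatic ring. Within the data shown here, no measured compound carries this exact group, so the evidence is indirect. Compound 2 is the closest guide, with 3-methylphenyl in that place, and the step that matters most is a 2.3-fold higher number from compound 2 to compound 3 (0.35 log units; beyond the scatter). Compound 1 has the methoxy group but as 3-methoxybenzyl, and replacing that with 3-methylphenyl gives a 2.7-fold lower number from compound 1 to compound 2 (0.43 log units; beyond the scatter). Both steps are modest, and three compounds offer only a narrow basis for prediction. A small move towards the lower number of compound 2 is therefore expected, probably not far beyond the scatter. The estimated change is a 1.5-fold lower number from compound 3 to compound 4 (0.18 log units; within the scatter). Compound 4 is expected to read 9000 nM, with an estimated range of 4500 nM to 18000 nM.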

Compound 4, concentration for 50% growth inhibition: 3470 nM
Compound 4: the middle estimate sits 2.6-fold (0.41 log units) above what was measured, and the stated range ends above it.
By their numbers in this assay, from the lowest: compounds 4 and 2 (each within the scatter of the next); then compounds 3 and 1 (each within the scatter of the next).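

In this assay, 3-methoxyphenyl on this nitrogen gives a 3.9-fold lower number from compound 3 to compound 4 (0.60 log units; beyond the scatter), and the same group gives a 4.7-fold lower number from compound 1 to compound 4 (0.67 log units; beyond the scatter) when it takes the place of 3-methoxybenzyl, which shows that the methoxy group alone does not set the reading: compound 1 carries it too and stays with compound 3 at the higher numbers. Methoxy in place of methyl on an aromatic carbon gives a 1.8-fold lower number from compound 2 to compound 4 (0.24 log units; within the scatter), so this change cannot be told apart from the usual scatter, and compound 2 and compound 4 now form a low pair, clearly apart from compound 1 and compound 3. The compounds shown offer no evidence that would explain any of these steps.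

As far as these compounds go, what remains open is whether the reading follows the place of the group on the phenyl ring, which 4-methoxyphenyl or 4-methylphenyl would test against the groups at hand. It is also unknown whether an amine, a hydroxy group or a carboxylic acid on the same ring would keep the number as low as in compound 2 and compound 4, or whether a longer chain such as 3-ethoxyphenyl would raise it.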